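Trifluoromethyl for Fluoro on a Second Core

The compounds below may be only part of what the source reports. "The series", "measured", "known", "first", "only" and "open" are said of these compounds alone.

Of the compounds shown here, three have been tested in a functional assay on A549 cells (Homo sapiens) for antiproliferative activity, read by MTT assay, with a stated time of 24 h; on this read-out lower numbers stand for stronger inhibition and higher numbers for weaker inhibition. Compound 1, `Cc1ccc(-c2nn(-c3ccccc3)cc2-c2nc3ccccc3n2S(=O)(=O)c2ccc(F)cc2)cc1`, gives 3240 nM in this assay. Compound 2, `Cc1ccc(-c2nn(-c3ccccc3)cc2-c2nc3ccccc3n2S(=O)(=O)c2ccc(C(F)(F)F)cc2)cc1`, differs from compound 1 in one place, (trifluoromethyl in place of fluoro on an aromatic carbon). In this assay compound 2 gives 1460 nM; the step is a 2.2-fold lower number from compound 1 to compound 2 (0.35 log units; beyond the scatter). Compound 3, `O=S(=O)(c1ccccc1)n1c(-c2cn(-c3ccccc3)nc2-c2ccc(F)cc2)nc2ccccc21`, belongs to a different core, and the difference between the two cores is not broken down here. In this assay compound 3 gives 550 nM, the lowest of the three numbers, with its steps to compound 2 and compound 1 both beyond the scatter.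

Compound 4, `O=S(=O)(c1ccccc1)n1c(-c2cn(-c3ccccc3)nc2-c2ccc(C(F)(F)F)cc2)nc2ccccc21`, has not yet been measured. It differs from compound 3 in one place, (trifluoromethyl in place of fluoro on an aromatic carbon). For the measured compounds named here, this is the same change that was made from compound 1 to compound 2, at the same kind of place, so the earlier step is the only guide available.

The step from compound 3 to compound 4 is expected to be a 2.0-fold lower number from compound 3 to compound 4 (0.31 log units; beyond the scatter), resting on the measured step of a 2.2-fold lower number from compound 1 to compound 2 (0.35 log units; beyond the scatter) and on the value of compound 3, 550 nM. On this basis compound 4 is estimated to give 270 nM in this assay, most likely somewhere between 120 nM and 650 nM.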

Compound 4, half-maximal inhibitory concentration: 480 nM
Estimate against measurement, compound 4: 1.8-fold (0.25 log units) below; low and high end bracket the measured number.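

In this assay, putting trifluoromethyl in place of fluoro on the second core gives a 1.1-fold lower number from compound 3 to compound 4 (0.06 log units; within the scatter), so the two compounds on this core cannot be told apart. Set beside the same change on the first core, the new step does not differ from the earlier one by more than repeated measurements of two such steps would: the same change on two cores in this assay, a 2.2-fold lower number (0.35 log units; beyond the scatter) from compound 1 to compound 2 and a 1.1-fold lower number (0.06 log units; within the scatter) from compound 3 to compound 4, 1.9-fold (0.29 log units) apart, within the scatter of two such steps. For the compounds shown here, this gives no ground for saying that the change behaves differently on the two cores, but it does not prove that the change carries over intact either: each core offers a single pair, and only the step on the first core lies beyond the scatter.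

The compounds shown leave open how other groups on the same aromatic carbon, such as a methoxy group, a nitrile or an amine, would compare with fluoro and trifluoromethyl on either core. They also leave open whether the two steps would stay this close on a third core or in a different cell line.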